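The compounds below may be only part of what the source reports. "The series", "measured", "known", "first", "only" and "open" are said of these compounds alone.

Measured compounds in a functional assay on HT-29 cells (Homo sapiens) for antiproliferative activity, read by sulforhodamine B assay, with a stated time of 48 h; a lower number here means a stronger inhibitor of growth, a higher number a weaker inhibitor of growth:
compound 1 `NS(=O)(=O)NCC1CCN(c2cc(-c3ccccc3)ncn2)CC1`;
compound 2 `Cc1ccc(-c2cc(N3CCC(CNS(N)(=O)=O)CC3)ncn2)cc1`, 33900 nM.

In this assay compound 1 reports only a limit, > 100000 nM. Going by the values given here, compound 2 therefore stands as the sole numeric value in the set. Among the compounds with values here, the single measured step is an at least 2.9-fold lower number from compound 1 to compound 2 (0.46 log units; beyond the scatter), with the limit of > 100000 nM in this assay, at which 1 of the 2 values shown sits, bounding its size from below. Compound 3 `CCCCc1ccc(-c2cc(N3CCC(CNS(N)(=O)=O)CC3)ncn2)cc1` differs from compound 2 by propyl in place of hydrogen on a saturated chain carbon bound to an aromatic carbon. Within the data shown here, no measured step covers extension of the chain itself, so the expectation rests on the methyl step alone. For compound 3 a further, modest decrease is expected, a 2.3-fold lower number from compound 2 to compound 3 (0.35 log units; beyond the scatter). Compound 3 is thus estimated at 15000 nM, range 4000 nM to 60000 nM.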

Compound 3, concentration for 50% growth inhibition: 15200 nM
Compound 3: the middle estimate sits 1.0-fold (0.01 log units) below what was measured, and the stated range covers the measured number.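

In this assay, propyl in place of hydrogen on a saturated chain carbon bound to an aromatic carbon gives a 2.2-fold lower number from compound 2 to compound 3 (0.35 log units; beyond the scatter). The number therefore keeps falling past the methyl, so this position accepts a chain as well as a single carbon. The full step is an at least 6.5-fold lower number from compound 1 to compound 3 (0.81 log units; beyond the scatter), a size known only as a bound: the limit of > 100000 nM in this assay, at which 1 of the 3 values shown sits.

From the compounds shown here alone, whether a longer chain, such as hexyl, lowers the number further remains open. So does whether an amine or a carboxylic acid at the chain end would be accepted at this position.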